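A few compounds are considered here, and "the series" means these few. Any claim that something is new, unique, unknown or untested is made for them only; others in the source may bear on it.

Measured in an ADME assay on liver (Rattus norvegicus) for metabolic stability, using microsomes; a lower number here means that the compound disappears faster, a higher number that the compound lasts longer
- compound 1 (`COc1ccc2cc1CCC(=O)Nc1ccc(S(=O)(=O)C3CC3)c(c1)CN(C)C(=O)[C@@H]2Nc1ccc2c(N)ncc(F)c2c1`) 0.267 h
- compound 2 (`CN1Cc2cc(ccc2S(=O)(=O)C2CC2)NC(=O)CCc2cc(ccc2C2CC2)[C@@H](Nc2ccc3c(N)ncc(F)c3c2)C1=O`) 0.0833 h

Compound 1 stands highest of the two measured compounds. Compound 3 (`COc1c(F)cc2cc1CCC(=O)Nc1ccc(S(=O)(=O)C3CC3)c(c1)CN(C)C(=O)[C@@H]2Nc1ccc2c(N)ncc(F)c2c1`) has not yet been measured and differs from compound 1 by one change: fluoro in place of hydrogen on an aromatic carbon (fluoro in place of hydrogen on an aromatic carbon, ortho to a methoxy group). Within the data shown here, only one measured step bears on this, and only loosely: a 3.2-fold lower number from compound 1 to compound 2 (0.51 log units; beyond the scatter) (cyclopropyl in place of methoxy on an aromatic carbon). Among the measured compounds shown here, that step replaces the methoxy group, which compound 3 keeps, and no measured step shows what a fluoro change does. With compound 1 at 0.267 h as the base, no shift beyond the scatter is expected in this assay. The expected step is a 1.1-fold higher number from compound 1 to compound 3 (0.05 log units; within the scatter) and would stay within the scatter. For compound 3 the estimated half-life is 0.3 h (expected range 0.15 h to 0.6 h).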

Compound 3, half-life: 0.133 h
Compound 3: middle estimate off by 2.3-fold (0.35 log units), on the high side; measured number outside the range, below it.
By their numbers in this assay, from the lowest: compounds 2, 3 and 1 (each within the scatter of the next, the first and the last beyond it).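

In this assay, among these compounds, fluoro in place of hydrogen on an aromatic carbon, ortho to a methoxy group, gives a 2.0-fold lower number from compound 1 to compound 3 (0.30 log units; within the scatter), the first reading for any change at this position. Unlike a 3.2-fold lower number from compound 1 to compound 2 (0.51 log units; beyond the scatter), which replaces the methoxy group and lies beyond the scatter, this change keeps the methoxy group and cannot be told apart from repeat measurement, so the series tolerates fluoro here without a resolved shift in half-life. No measurement at hand accounts for this result.

Going by these compounds, whether chloro, methyl or a nitrile on this same aromatic carbon would move the half-life beyond the scatter remains open. Also open, on these data alone, is how fluoro at this position would read with cyclopropyl in place of the methoxy group, as in compound 2.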